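Cytotoxicity notes on compounds 1 to 4

The source may report more compounds than this note shows. Statements on the series, on what has been measured and on what is new or still open speak of the compounds shown alone.

Measured so far:
compound 1, `CCC1(Cc2ccccc2)OS(=O)(=O)C=C1OCc1ccc([N+](=O)[O-])cc1`: >= 80000 nM
compound 2, `CC(C)C1(Cc2ccccc2)OS(=O)(=O)C=C1OCc1ccccc1`: >= 80000 nM
compound 3, `CCC1(Cc2ccccc2)OS(=O)(=O)C=C1NCc1ccccc1`: >= 80000 nM

All three values come from an ADME assay on HEL cells (Homo sapiens) for cytotoxicity, with a stated time of 3 days; on this read-out higher numbers stand for lower toxicity in this test and lower numbers for higher toxicity in this test. For compound 1 the value >= 80000 nM is a limit of the assay, not a number. The same holds for compound 2, whose value >= 80000 nM is also a limit. For compound 3 the value >= 80000 nM is a limit as well. Among the measured compounds shown here, what the set shows is the limit of >= 80000 nM in this assay, at which 3 of the 3 values shown sit; no compound has yet given a number below that limit, and no step between measured compounds can be sized.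

Compound 4, `CCC1(Cc2ccccc2)OS(=O)(=O)C=C1OCCCCc1ccccc1`, is the next one to be measured in this assay. It differs from compound 1 in one place: 3-phenylpropyl in place of 4-nitrophenyl on a saturated chain carbon bound to an oxygen on an unsaturated carbon. For the measured compounds named here, nothing among the measured compounds shows a change at this position moving the read-out off the limit, so no step beyond the usual scatter is expected from compound 1 to compound 4, in either direction. The expected outcome for compound 4 is 80000 nM, with a range from 40000 nM to 160000 nM, most likely reported again as a limit rather than a number. The expected step is a number no higher from compound 1 to compound 4 (the limit leaves the size open).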

Compound 4, minimum cytotoxic concentration: >= 20000 nM
Compound 4 ended at the assay's limit; the forecaster's own chance of this, stated with the estimate: 80%; the middle value is on the limit's open side.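

Among the compounds shown here, compound 1 and compound 4 both stand at limits of the assay, not numbers, so no step between them can be read in this assay for 3-phenylpropyl in place of 4-nitrophenyl. The compounds shown leave open the concentration at which any of them would turn cytotoxic to these cells, and whether that replacement shifts it.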